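From an ether chain to a hydroxyl-ended chain

A few compounds are considered here, and "the series" means these few. Any claim that something is new, unique, unknown or untested is made for them only; others in the source may bear on it.

In a functional assay on SK-MEL-5 cells (Homo sapiens) for antiproliferative activity (on this read-out higher numbers stand for weaker inhibition of growth and lower numbers for stronger inhibition of growth), compound 1 (`COC(=O)CCCCCCCCCCCCCC/C=C1\CC(CO)(COC(=O)C(C)(C)C)OC1=O`) gives 7.8 ug/mL and compound 2 (`CCCCCOCCCCCCC/C=C1\CC(CO)(COC(=O)C(C)(C)C)OC1=O`) gives 2.99 ug/mL as the lower of the two numbers. Among the compounds with values here, the nearest value to compound 2 is therefore that of compound 1, and the gap between them is the only measured step (a 2.6-fold lower number from compound 1 to compound 2 (0.42 log units; beyond the scatter)). It is modest but beyond the scatter.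

Compound 3 (`CC(C)(C)C(=O)OCC1(CO)C/C(=C\CCCCCCCCCCCO)C(=O)O1`) carries 4-hydroxybutyl in place of pentyloxy on a saturated chain carbon, seven bonds along the chain from a double-bonded chain carbon. Within the data shown here, no measured pair makes this exact exchange. Among the measured compounds shown here, the only guide is the change at the same place that separates compound 2 from compound 1 (a 2.6-fold lower number from compound 1 to compound 2 (0.42 log units; beyond the scatter)). On that single step, a large shift is not expected, and the expectation leans only slightly toward a higher number, without clearly passing the scatter. The expected change is small (a 1.5-fold higher number from compound 2 to compound 3 (0.18 log units; within the scatter)) and rests on little evidence. For compound 3 the estimate is 4.5 ug/mL with an expected range from 1.8 ug/mL to 11 ug/mL on this read-out.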

Compound 3, concentration for 50% growth inhibition: 5.81 ug/mL
Compound 3: the middle estimate sits 1.3-fold (0.11 log units) below what was measured; the measured number falls inside the stated range.
By their numbers in this assay, from the lowest: compounds 2, 3 and 1 (each within the scatter of the next, the first and the last beyond it).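

In this assay, 4-hydroxybutyl in place of pentyloxy on a saturated chain carbon, seven bonds along the chain from a double-bonded chain carbon, stays within the scatter (a 1.9-fold higher number from compound 2 to compound 3 (0.29 log units; within the scatter)), so this read-out does not separate a chain with 1 hydrogen-bond donor from the ether chain with none. Within the data shown here, the hydroxyl-ended chain is equally unseparated from the ester-ended chain (a 1.3-fold lower number from compound 1 to compound 3 (0.13 log units; within the scatter)), which places compound 3 within the scatter of both of the earlier compounds, even though those two lie beyond the scatter of each other (a 2.6-fold lower number from compound 1 to compound 2 (0.42 log units; beyond the scatter)). No supporting measurement bears on what lies behind these numbers.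

The compounds shown leave open whether an amine or a carboxylic acid at the end of the chain would stand apart from the hydroxyl in this assay, and whether a longer chain ending in the same hydroxyl would do so. They also leave open whether the small step seen here would hold on any core other than the shared one.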